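The source may hold more compounds than are shown below. What is called first, only, known or untested is meant among the compounds shown, and "the series" means these compounds.

The measured compounds:
compound 1, `COc1ccc(C2SCC(=O)N2n2c(CSc3nnc(-c4ccncc4)o3)nc3ccc(Br)cc3c2=O)cc1`, which in a functional assay on the whole organism (strain Charles-Foster albino) for inhibition, with Rattus norvegicus as the target, read by paw edema, at a dose of 50 mg/kg by the oral route (on this read-out lower numbers stand for less inhibition and higher numbers for more inhibition at the one dose given (going by the name of the read-out)), gives 35.3%;
compound 2, `O=C1CSC(c2ccc(Cl)cc2)N1n1c(CSc2nnc(-c3ccncc3)o2)nc2ccc(Br)cc2c1=O`, which in this assay gives 25.2%;
compound 3, `O=c1c2cc(Br)ccc2nc(CSc2nnc(-c3ccncc3)o2)n1/N=C/c1ccc(Cl)cc1`, which in this assay gives 26.4%.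

Compound 1 and compound 2 share one core and differ in a single place: methoxy in place of chloro on an aromatic carbon. This change made a step of a number 10.1 percentage points higher from compound 2 to compound 1 (beyond the scatter). Compound 3 is built on a different core; the difference between the core of compound 2 and the core of compound 3 is not broken down here. The value of compound 3 lies within the scatter of that of compound 2, and also within the scatter of that of compound 1, so no order among these three can be read from the numbers.

Compound 4, `COc1ccc(/C=N/n2c(CSc3nnc(-c4ccncc4)o3)nc3ccc(Br)cc3c2=O)cc1`, has not yet been measured in this assay. Among the compounds with values here, it differs from compound 3 by methoxy in place of chloro on an aromatic carbon, the same change as the one between compound 2 and compound 1, now made on the core of compound 3. For compound 4 the expected step is a number 9.6 percentage points higher from compound 3 to compound 4 (within the scatter), set beside the earlier step and about as large, because the same change on the other core gave a number 10.1 percentage points higher from compound 2 to compound 1 (beyond the scatter). This rests on a single pair of measured compounds, so the range is kept wide. In this assay compound 4 is therefore estimated at 36%, with a range from 25% to 47%.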

Compound 4, a percentage reported as inhibition, in the whole organism at one dose (the size of the read-out at that dose, not a potency): 24.4%
Estimate against measurement, compound 4: 11.6 percentage points above, and the stated range ends above it.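

Carried onto the core of compound 3, methoxy in place of chloro gave in this assay a step of a number 2 percentage points lower from compound 3 to compound 4 (within the scatter), so no effect of the change can be read on this core. Set side by side, the results on the two cores cannot be told apart: the same change on two cores in this assay, a number 10.1 percentage points higher (beyond the scatter) from compound 2 to compound 1 and a number 2 percentage points lower (within the scatter) from compound 3 to compound 4, 12.1 percentage points apart, within the scatter of two such steps. Within the data shown here, this does not show that the change carries over from one core to the other, nor does it show that the two cores respond to it differently, for each core offers only a single pair of compounds, and only the step on the core of compound 1 lies beyond the scatter.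

The compounds shown carry only a 4-chlorophenyl or a 4-methoxyphenyl group at this place, so it stays open whether an amine, a carboxylic acid or a longer alkoxy chain at the same position would give comparable steps on the two cores. The bromine is also common to all four compounds, which leaves open how either core would behave with a hydrogen or a fluorine there, and whether the methoxy step would then be any clearer.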